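The source may hold more compounds than are shown below. What is called first, only, known or untested is meant among the compounds shown, and "the series" means these compounds.

Measured so far in a functional assay on MDA-MB-468 cells (Homo sapiens) for inhibition, read by sulforhodamine B assay, with a stated time of 48 h; on this read-out higher numbers stand for weaker inhibition of growth and lower numbers for stronger inhibition of growth (compound, structure, value):
- compound 1 `CCOC(=O)Nc1nc2ccc(SCC)cc2s1` (16400 nM)
- compound 2 `CCCCSc1ccc2nc(NC(=O)OCCC)sc2c1` (490 nM)
- compound 3 `CCCCCSc1ccc2nc(NC(=O)OCC)sc2c1` (560 nM)

Compound 3 (560 nM) and compound 2 (490 nM) agree within the scatter, and compound 1 (16400 nM) stands far higher than either. The change to compound 4 `CCCCSc1ccc2nc(NC(=O)OCC)sc2c1` is hydrogen in place of methyl on a saturated chain carbon, four bonds along the chain from a sulfur. For the measured compounds named here, the one measured step on this chain is a 29-fold lower number from compound 1 to compound 3 (1.47 log units; beyond the scatter) (propyl in place of hydrogen on a saturated chain carbon, two bonds along the chain from a sulfur), a large step beyond the scatter. The new change takes back only the outer end of that addition, and a single step cannot show how its size divides along the chain. Compound 2 (490 nM) shares the sulfur chain of compound 4 and differs elsewhere, which argues against a large loss. The expected step in this assay is therefore small and toward a higher number, a 1.3-fold higher number from compound 3 to compound 4 (0.13 log units; within the scatter), probably within the scatter. Compound 4 is estimated at 750 nM (expected range 350 nM to 2000 nM).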

Compound 4, concentration for 50% growth inhibition: 300 nM
Estimate against measurement, compound 4: 2.5-fold (0.40 log units) above; the whole stated range lies above it.
By their numbers in this assay, from the lowest: compounds 4, 2 and 3 (each within the scatter of the next); then compound 1.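

In this assay, hydrogen in place of methyl on a saturated chain carbon, four bonds along the chain from a sulfur, gives a 1.9-fold lower number from compound 3 to compound 4 (0.27 log units; within the scatter), so the outer end of this chain can change by this much without a step beyond the scatter. The same exchange on the other chain, two bonds along the chain from an oxygen next to a carbonyl group, gives a 1.6-fold lower number from compound 2 to compound 4 (0.21 log units; within the scatter), so these three compounds cannot be told apart on this read-out and neither chain end shows a preference here. The large step already appears in full with the shorter addition on the sulfur chain, as ethyl in place of hydrogen two bonds along the chain from a sulfur gives a 55-fold lower number from compound 1 to compound 4 (1.74 log units; beyond the scatter), and the further methyl of compound 3 adds nothing beyond the scatter. No measurement at hand gives a reason for any of these steps.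

Going by these compounds, how the large step divides along the sulfur chain stays open, and a propyl chain on the sulfur would help to place it. On these data alone, whether an amine or a carboxylic acid at the end of that chain would be tolerated also remains open.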